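The source may hold more compounds than are shown below. What is called first, only, known or untested is meant among the compounds shown, and "the series" means these compounds.

Measured so far in a functional assay on T47D cells (Homo sapiens) for cytotoxicity, read by colorimetric assay and MTT assay; on this read-out higher numbers stand for weaker inhibition and lower numbers for stronger inhibition:
- compound 1 `CCN(CC)C(=O)Cn1c(=O)c(-c2ccc(OC)cc2)cc2c(OC)cc(OC)cc21`: 10000 nM
- compound 2 `COc1ccc(-c2cc3c(OC)cc(OC)cc3n(CC#N)c2=O)cc1`: 10000 nM
- compound 3 `COc1ccc(-c2cc3c(OC)cc(OC)cc3n(CCC#N)c2=O)cc1`: 10000 nM

Compound 3 stands level with compound 1 and compound 2, with nothing separating the three values. The next step leads to compound 4 `COc1ccc(-c2cc3c(OC)cc(OC)cc3n(CCC(=O)OCc3ccccc3)c2=O)cc1`, with benzyloxycarbonyl in place of cyano on a saturated chain carbon, two bonds along the chain from an aromatic nitrogen.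

Among the measured compounds shown here, three measured steps bear on this position: no change at the digits printed from compound 1 to compound 2 (within the scatter), no change at the digits printed from compound 1 to compound 3 (within the scatter) and no change at the digits printed from compound 2 to compound 3 (within the scatter). None of them moved the read-out, although the groups exchanged differ considerably. For the measured compounds named here, no measured compound carries benzyloxycarbonyl, so this is an extrapolation, and the new group is much larger than the one it replaces.

In this assay, the expected step is a 1.3-fold lower number from compound 3 to compound 4 (0.10 log units; within the scatter), with no clear shift beyond the scatter anticipated. The estimate for compound 4 is 8000 nM, with an expected range of 2500 nM to 15000 nM.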

Compound 4, half-maximal inhibitory concentration: 10000 nM
Compound 4: middle estimate off by 1.3-fold (0.10 log units), on the low side; the measured number falls inside the stated range.
By their numbers in this assay, from the lowest: compounds 1, 2, 3 and 4 (each within the scatter of the next).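

In this assay, benzyloxycarbonyl in place of cyano on a saturated chain carbon, two bonds along the chain from an aromatic nitrogen, gives no change at the digits printed from compound 3 to compound 4 (within the scatter), so even a group bearing a six-membered aromatic ring leaves the read-out where the smaller groups left it. The comparisons with the other two compounds read the same way: (benzyloxycarbonyl)methyl in place of cyano gives no change at the digits printed from compound 2 to compound 4 (within the scatter), and in place of diethylcarbamoyl it gives no change at the digits printed from compound 1 to compound 4 (within the scatter). No supporting data accompany this result.

The compounds shown leave open whether any group at this place can move the read-out in this assay at all. A carboxylic acid or an amine at the end of this chain would test that further, as would a hydroxy group in place of a methoxy group on the shared core.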